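From Nitro to Bare Phenyl: An Expected Modest Loss

The compounds below may be only part of what the source reports. "The series", "measured", "known", "first", "only" and "open" are said of these compounds alone.

Measured in a functional assay on MDA-MB-231 cells (Homo sapiens) for inhibition, read by MTT assay, with a stated time of 48 h (a lower number here means a stronger inhibitor, a higher number a weaker inhibitor), for three compounds:
- Compound 1 `COc1cc(-c2cc(-c3ccc(Br)cc3)nc(-c3ccccc3)n2)cc(OC)c1OC` at > 25000 nM (a limit, not a number)
- Compound 2 `COc1cc(-c2cc(-c3cccc([N+](=O)[O-])c3)nc(-c3ccccc3)n2)cc(OC)c1OC` at 2440 nM
- Compound 3 `COc1cc(-c2cc(-c3cccc(O)c3)nc(-c3ccccc3)n2)cc(OC)c1OC` at 1990 nM

Among the compounds with values here, compound 2 (2440 nM) and compound 3 (1990 nM) lie within the scatter of each other, and these are the only two numbers available. The next step leads to compound 4 `COc1cc(-c2cc(-c3ccccc3)nc(-c3ccccc3)n2)cc(OC)c1OC` with hydrogen in place of nitro on an aromatic carbon, turning 3-nitrophenyl to phenyl.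

Within the data shown here, three measured steps bear on this change. The closest is hydroxy in place of nitro (a 1.2-fold lower number from compound 2 to compound 3 (0.09 log units; within the scatter)), which stays within the scatter. The other two are large (an at least 10-fold lower number from compound 1 to compound 2 (1.01 log units; beyond the scatter) and an at least 12-fold lower number from compound 1 to compound 3 (1.09 log units; beyond the scatter)) and both start from the limit of compound 1, so the group at this place can move the number far. Among the measured compounds shown here, none of the measured compounds carries the plain phenyl, so the data do not show its effect directly.

With compound 2 so close to compound 3 (a 1.2-fold lower number from compound 2 to compound 3 (0.09 log units; within the scatter)), a modest step towards a higher number is expected in this assay rather than a large one (a 2.0-fold higher number from compound 2 to compound 4 (0.31 log units; beyond the scatter)). Compound 4 is estimated at 5000 nM (expected range 1500 nM to 18000 nM).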

Compound 4, half-maximal inhibitory concentration: 5870 nM
Compound 4: the middle estimate sits 1.2-fold (0.07 log units) below what was measured, within the range that was stated.
By their numbers in this assay, from the lowest: compounds 3 and 2 (each within the scatter of the next); then compound 4. At a limit, above all of these: compound 1.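

In this assay, within the data shown here, compound 4 gives the first reading of this position with no group on the ring, and taking the nitro away carries a cost beyond the scatter: a 2.4-fold higher number from compound 2 to compound 4 (0.38 log units; beyond the scatter). Taking the hydroxy away does the same, a 2.9-fold higher number from compound 3 to compound 4 (0.47 log units; beyond the scatter), so the closeness of compound 2 and compound 3 now reads as two different groups that each give a lower number than plain phenyl, not as a sign that the place is indifferent to what sits there. The 4-bromophenyl of compound 1 goes against this, since plain phenyl is the better of the two there, an at least 4.2-fold lower number from compound 1 to compound 4 (0.62 log units; beyond the scatter), though that step has a limit at one end and not a number, so its true size stays unknown: the limit of > 25000 nM in this assay, at which 1 of the 4 values shown sits.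

The compounds shown leave open whether an amine or a carboxylic acid in the place of that hydrogen would also give a lower number than plain phenyl. Bromo appears only in 4-bromophenyl, and nitro and hydroxy only in 3-nitrophenyl and 3-hydroxyphenyl, so the effect of the group and the effect of its place cannot yet be told apart.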